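The compounds below may be only part of what the source reports. "The series", "measured", "known", "first", "only" and "open" are said of these compounds alone.

Compound 2 `CCCCCOC(=O)OCC(CO)CCn1cnc2cnc(N)nc21` stands level with compound 1 `CCOC(=O)OCC(CO)CCn1cnc2cnc(N)nc21`: in an ADME assay for pharmacokinetics, read by HPLC, in phosphate buffer, at 37 degrees C, at pH 7.4 (on this read-out higher numbers stand for a longer-lived compound and lower numbers for a shorter-lived compound), compound 1 gives 168 h, and compound 2 gives 168 h. Within the data shown here, the only measured step, no change at the digits printed from compound 1 to compound 2 (within the scatter), is also the only one that bears on the change ahead, since it too alters the chain on the oxygen next to the carbonyl. Compound 3 `CC(C)OC(=O)OCC(CO)CCn1cnc2cnc(N)nc21` differs from compound 2 as follows: isopropyl in place of pentyl on an oxygen next to a carbonyl group. Because no change at the digits printed from compound 1 to compound 2 (within the scatter) stayed within the scatter, compound 3 is expected to show no step beyond the scatter in this assay, that is no change at the digits printed from compound 2 to compound 3 (within the scatter). Compound 3 is therefore estimated at 168 h, between 84 h and 336 h.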

Compound 3, half-life: 1460 h
For compound 3 the middle estimate is 8.7-fold (0.94 log units) below the measured one; measured number above the stated range.
By their numbers in this assay, from the lowest: compounds 1 and 2 (each within the scatter of the next); then compound 3.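

In this assay, the group on this oxygen can matter after all: isopropyl in place of pentyl gives an 8.7-fold higher number from compound 2 to compound 3 (0.94 log units; beyond the scatter), and methyl in place of hydrogen on the saturated chain carbon bound to that oxygen gives an 8.7-fold higher number from compound 1 to compound 3 (0.94 log units; beyond the scatter). The longer chain of compound 2 left it level with compound 1, so only the isopropyl of compound 3 stands apart from the other two. Nothing available here explains this difference. As far as these compounds go, whether a tert-butyl or a cyclopropyl on this oxygen would raise the number further stays open.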